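The source may report more compounds than this note shows. Statements on the series, on what has been measured and on what is new or still open speak of the compounds shown alone.

Measured so far: compound 1 `CN(C)CC(=O)N1CCC(NS(=O)(=O)c2cc(S(=O)(=O)c3ccccc3)ccc2C(F)(F)F)CC1`, which in an assay on isolated protein for binding affinity to secreted frizzled-related protein 1 (Homo sapiens), read by fluorescence (a higher number here means a weaker inhibitor, a lower number a stronger inhibitor), gives 300 nM; compound 2 `CC(C)(C)CC(=O)N1CCC[C@H]1C(=O)N1CCC(NS(=O)(=O)c2cc(S(=O)(=O)c3ccccc3)ccc2C(F)(F)F)CC1`, which in this assay gives 20 nM.

Compound 2 holds the lowest number of the two. Compound 3 `CN1CCC[C@H]1C(=O)N1CCC(NS(=O)(=O)c2cc(S(=O)(=O)c3ccccc3)ccc2C(F)(F)F)CC1` differs from it by methyl in place of neopentylcarbonyl on an amine nitrogen in a ring. Among the measured compounds shown here, the only step that bears on this change is a 15-fold lower number from compound 1 to compound 2 (1.18 log units; beyond the scatter), where the neopentylcarbonyl-bearing pyrrolidine entered; compound 3 keeps the pyrrolidine but gives up the neopentylcarbonyl. The expected step in this assay is therefore upward, of middling size, a 7.5-fold higher number from compound 2 to compound 3 (0.88 log units; beyond the scatter). Compound 3 is estimated at 150 nM, within 50 nM to 500 nM.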

Compound 3, half-maximal inhibitory concentration: 120 nM
Estimate against measurement, compound 3: 1.3-fold (0.10 log units) above; the measured number falls inside the stated range.
By their numbers in this assay, from the lowest: compound 2; then compound 3; then compound 1.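

In this assay, replacing neopentylcarbonyl with methyl on the amine nitrogen in the ring gives a 6.0-fold higher number from compound 2 to compound 3 (0.78 log units; beyond the scatter) and so loses part of the earlier gain. Yet 1-methylpyrrolidin-2-yl in place of (dimethylamino)methyl still gives a 2.5-fold lower number from compound 1 to compound 3 (0.40 log units; beyond the scatter), so the methylated ring keeps part of that gain without the neopentylcarbonyl. Nothing given here accounts for either step.

As far as these compounds go, whether acetyl on that nitrogen, or a free amine with only hydrogen there, would hold the number near that of compound 2 or compound 3 remains open.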